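Chloro for bromo on the five-membered ring, two cores

A few compounds are considered here, and "the series" means these few. Any claim that something is new, unique, unknown or untested is made for them only; others in the source may bear on it.

Measured so far:
compound 1, `FC(F)(F)c1ccc(-c2noc(-c3occc3Br)n2)cc1`: 320 nM
compound 2, `FC(F)(F)c1ccc(-c2noc(-c3occc3Cl)n2)cc1`: 170 nM
compound 3, `Clc1ccc(-c2noc(-c3occc3Br)n2)nc1`: 380 nM

All three numbers come from a functional assay on T47D cells (Homo sapiens) for inhibition, with a stated time of 48 h, at 37 degrees C; on this read-out higher numbers stand for weaker inhibition of growth and lower numbers for stronger inhibition of growth. Compound 1 and compound 2 share a core and differ only by chloro in place of bromo on an aromatic carbon; this gave a 1.9-fold lower number from compound 1 to compound 2 (0.27 log units; within the scatter), so on that core the exchange did not move the number beyond the usual scatter. Compound 3 carries a different core; how its core differs from that of compound 1 is not broken down here. Compound 3 and compound 1 lie within the scatter of each other, so no order between them is claimed. Against compound 2, compound 3 shows a higher number, and that gap lies beyond the scatter.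

Compound 4, `Clc1ccc(-c2noc(-c3occc3Cl)n2)nc1`, is the not yet measured partner of compound 3 and differs from it by chloro in place of bromo on an aromatic carbon. This is the same change as between compound 1 and compound 2, at a place described in the same words, now made on the second core. The step from compound 3 to compound 4 is expected to be a 1.7-fold lower number from compound 3 to compound 4 (0.22 log units; within the scatter), small and downward, because on the first core the same exchange gave a 1.9-fold lower number from compound 1 to compound 2 (0.27 log units; within the scatter). Whether the second core answers in the same way cannot be checked from these three compounds alone. Compound 4 is estimated to give 230 nM, with the likely range from 100 nM to 520 nM.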

Compound 4, concentration for 50% growth inhibition: 13000 nM
For compound 4 the middle estimate is 57-fold (1.75 log units) below the measured one; measured number outside the range, above it.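

Replacing 3-bromofuran-2-yl with 3-chlorofuran-2-yl on the core of compound 3 gave, in this assay, a 34-fold higher number from compound 3 to compound 4 (1.53 log units; beyond the scatter), so the small step seen on the core of compound 1 did not carry over to this second core. Among the compounds shown here, the two steps do not agree, and the gap between them is larger than repeated measurements would explain: the same change on two cores in this assay, a 1.9-fold lower number (0.27 log units; within the scatter) from compound 1 to compound 2 and a 34-fold higher number (1.53 log units; beyond the scatter) from compound 3 to compound 4, 64-fold (1.81 log units) apart, beyond the scatter of two such steps This shows that, in this series, the result of this exchange on one core cannot be taken as a guide to its result on the other, but with only one pair on each core it does not show why the cores part, and it assigns no property to the chloro group, the bromo group or either core.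

The compounds shown leave open how a group other than bromo or chloro, such as a methyl group, a nitrile or an amine, would behave at this place on the five-membered ring on either core. They also leave open whether the large rise in the number belongs only to chloro on the core of compound 3 or would recur on a third core.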